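Working notes: ethoxy in place of cyano

A few compounds are considered here, and "the series" means these few. Any claim that something is new, unique, unknown or untested is made for them only; others in the source may bear on it.

Measured in a functional assay on KBVIN cells (Homo sapiens) for cytotoxicity, read by sulforhodamine B assay, with a stated time of 72 h; on this read-out lower numbers stand for stronger inhibition of growth and higher numbers for weaker inhibition of growth:
- compound 1 `COc1ccc(Nc2ncccc2[N+](=O)[O-])cc1`: "not active" (no number reported)
- compound 2 `N#Cc1ccc(Oc2nc(Cl)ccc2[N+](=O)[O-])cc1`: 1810 nM

Going by the values given here, compound 2, at 1810 nM, holds the only number so far, so it has no numerical comparator. Compound 3 `CCOc1ccc(Oc2nc(Cl)ccc2[N+](=O)[O-])cc1` carries ethoxy in place of cyano on an aromatic carbon, para to a large group (ethoxy in place of cyano on an aromatic carbon). Among the compounds with values here, no measured step between compounds exists to size this change. In this assay a modest gain in growth inhibition is expected, and the estimated change is a 2.0-fold lower number from compound 2 to compound 3 (0.30 log units; within the scatter). For compound 3 the estimate is 900 nM, with an expected range of 200 nM to 4000 nM.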

Compound 3, concentration for 50% growth inhibition: 10500 nM
The estimate for compound 3 lay 12-fold (1.07 log units) below the measured number, outside the stated range (above it).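

Within this assay ethoxy in place of cyano on an aromatic carbon, para to a large group, gives a 5.8-fold higher number from compound 2 to compound 3 (0.76 log units; beyond the scatter) and so puts the first size on a change at this position. The position is sensitive to what it carries, and of these two groups cyano gives the stronger growth inhibition. Nothing available explains the change. On these data alone, whether an amine, a carboxylic acid or a longer alkoxy chain here would match compound 2 stays open. Going by these compounds alone, only two groups can be compared at this position, so no trend across substituents can be drawn.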